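Compound 3: acid in place of methyl ester

This account rests on a few compounds, and the source may have more. Where it says the series, first, only, none or still open, it means among the compounds named here.

Measured in a functional assay on HL-60 cells (Homo sapiens) for cytotoxicity (on this read-out lower numbers stand for stronger inhibition and higher numbers for weaker inhibition), so far:
- compound 1 `COc1c(C)c(/C=C/C(=O)O)oc(=O)c1CO` reads > 50000 nM (a limit)
- compound 2 `COC(=O)/C=C/c1oc(=O)c(CO)c(OC)c1CO` reads > 50000 nM (a limit)

Compound 2 stands at the limit of this assay with > 50000 nM as its reading, which is a limit and not a number. Compound 1 likewise reads > 50000 nM and that too is a limit. The whole picture so far is the limit of > 50000 nM in this assay, at which 2 of the 2 values shown sit, and no numerical reading exists to rank the two compounds.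

The next compound is compound 3 `COc1c(CO)c(/C=C/C(=O)O)oc(=O)c1CO` and its change from compound 2 is hydrogen in place of methyl on an oxygen next to a carbonyl group with hydrogen in place of methyl on an oxygen next to a carbonyl group, so that methoxycarbonyl becomes carboxy. Within the data shown here, no measured step is available as a guide. With compound 2 at > 50000 nM there is no sign of activity for this change to build on, so no shift beyond the scatter is expected in this assay in either direction. The expected a number no higher from compound 2 to compound 3 (the limit leaves the size open) is therefore close to nil. For compound 3 the estimate is 50000 nM with an expected range from 20000 nM to 100000 nM and a limit rather than a number is the likeliest report.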

Compound 3, half-maximal inhibitory concentration: > 50000 nM
Compound 3: no number, only a limit; the forecaster's own chance of this, stated with the estimate: 80%; the middle value lies on the limit itself.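

In this assay compound 3 gives > 50000 nM as a limit and not as a number. No step from compound 1 or compound 2 to compound 3 can be read: the limit of > 50000 nM in this assay, at which 3 of the 3 values shown sit.

The compounds shown leave open whether any variation on the shared core gives a numerical reading in this assay and, with that, how methoxycarbonyl and carboxy compare.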